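Diethylamino for dimethylamino on two related cores

The compounds below may be only part of what the source reports. "The series", "measured", "known", "first", "only" and "open" are said of these compounds alone.

Measured so far in a functional assay on HL60/MX2 cells (Homo sapiens) for antiproliferative activity, read by MTT assay, with a stated time of 48 h; a higher number here means a weaker inhibitor, a lower number a stronger inhibitor:
compound 1 `CN(C)CCCCn1c(N)c(-c2nc3ccccc3o2)c2nc(C#N)c(C#N)nc21` gives 960 nM
compound 2 `CCN(CC)CCCCn1c(N)c(-c2nc3ccccc3o2)c2nc(C#N)c(C#N)nc21` gives 1720 nM
compound 3 `CN(C)CCCCn1c(-c2c(N)n(C)c3nc(C#N)c(C#N)nc23)nc2ccccc21` gives 2810 nM

Compound 1 and compound 2 share one core and differ only at the end of the chain: diethylamino in place of dimethylamino on a saturated chain carbon, four bonds along the chain from an aromatic nitrogen. That change made a 1.8-fold higher number from compound 1 to compound 2 (0.25 log units; within the scatter). Compound 3 carries a different core; how the core of compound 3 differs from the core of compound 1 is not broken down here. In this assay compound 3 gives a higher number than compound 1, a gap beyond the scatter, while the numbers of compound 3 and compound 2 lie within the scatter of each other.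

Compound 4 `CCN(CC)CCCCn1c(-c2c(N)n(C)c3nc(C#N)c(C#N)nc23)nc2ccccc21` has not yet been measured in this assay. It stands to compound 3 as compound 2 stands to compound 1: diethylamino in place of dimethylamino on a saturated chain carbon, four bonds along the chain from an aromatic nitrogen. Both place lines read the same, so this is the same change on the other core. Within the data shown here, the only guide is the step seen on the first core, which stayed within the scatter; on that ground the expected step is a 1.5-fold higher number from compound 3 to compound 4 (0.17 log units; within the scatter), beside the earlier one, because compound 1 to compound 2 gave a 1.8-fold higher number from compound 1 to compound 2 (0.25 log units; within the scatter). Compound 4 is therefore estimated at 4200 nM, with an expected range from 2000 nM to 9000 nM.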

Compound 4, half-maximal inhibitory concentration: 3920 nM
Compound 4: the middle estimate sits 1.1-fold (0.03 log units) above what was measured, and the stated range covers the measured number.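

In this assay, diethylamino in place of dimethylamino on a saturated chain carbon, four bonds along the chain from an aromatic nitrogen, gives a 1.4-fold higher number from compound 3 to compound 4 (0.14 log units; within the scatter) on the second core, so the step again stays within the scatter. Neither step can be told apart from repeat measurement, so these numbers do not establish a real difference between the dimethylamino and diethylamino compounds on either core, and two matched pairs cannot show that the step would hold on any further core. What can be said is limited to these two cores, where the change reads alike and the two steps cannot be separated: the same change on two cores in this assay, a 1.8-fold higher number (0.25 log units; within the scatter) from compound 1 to compound 2 and a 1.4-fold higher number (0.14 log units; within the scatter) from compound 3 to compound 4, 1.3-fold (0.11 log units) apart, within the scatter of two such steps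

The compounds shown leave open whether a ring amine at the chain end, such as pyrrolidine, piperidine or morpholine, or a larger dialkylamine such as dipropylamino, would stay as close to dimethylamino as diethylamino does here. They also leave open whether the same change would read alike on a shorter chain, as in 3-(dimethylamino)propyl to 3-(diethylamino)propyl, or on a longer chain than the one carried by all four compounds.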